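The compounds below may be only part of what the source reports. "The series", "measured", "known", "first", "only" and "open" are said of these compounds alone.

Of the compounds shown here, three built on one shared core have been tested in a functional assay on HCT-116 cells (Homo sapiens) for antiproliferative activity, read by MTT assay, with a stated time of 48 h; on this read-out lower numbers stand for stronger inhibition and higher numbers for weaker inhibition. Compound 1 `N#CC1=C(N)Oc2c(c3nc4ccccc4nc3c3ccccc23)C12C(=O)N(Cc1cnnn1-c1ccc(S(N)(=O)=O)cc1)c1ccccc12` gives 31200 nM. Compound 2 `Cc1cc(C)cc(-n2nncc2CN2C(=O)C3(C(C#N)=C(N)Oc4c3c3nc5ccccc5nc3c3ccccc43)c3ccccc32)c1` returns only a limit of the assay, > 50000 nM, and not a number. As far as these compounds go, compound 3 `N#CC1=C(N)Oc2c(N)cc3nc4ccccc4nc3c2C12C(=O)N(Cc1cnnn1-c1ccc(Cl)cc1)c1ccccc12` also returns only a limit, > 50000 nM, so its true number is unknown. Compound 3 thus stands at the limit of > 50000 nM in this assay, at which 2 of the 3 values shown sit, which is where two of the three values sit.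

Among the compounds with values here, the only step between two measured compounds that differ in a single place is an at least 1.6-fold higher number from compound 1 to compound 2 (0.20 log units; that floor lies within the scatter). That change also replaced the aryl group on the aromatic nitrogen of the five-membered ring, and it did not move the read-out beyond the scatter.

Compound 4 `COc1ccc(OC)c(-n2nncc2CN2C(=O)C3(C(C#N)=C(N)Oc4c(N)cc5nc6ccccc6nc5c43)c3ccccc32)c1` has not been measured. It differs from compound 3 by 2,5-dimethoxyphenyl in place of 4-chlorophenyl on an aromatic nitrogen. Within the data shown here, the one measured step of this kind was small, and compound 3 already sits at the limit, so no large move is expected in this assay . Compound 4 is expected to give about 60000 nM, within a range of 20000 nM to 200000 nM. The estimated step is a step that the limit leaves unreadable from compound 3 to compound 4, most likely ending again at a limit rather than a number.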

Compound 4, half-maximal inhibitory concentration: > 50000 nM
Compound 4: a limit, no number (the forecaster's own chance of this, stated with the estimate: 75%); the middle value does not contradict the limit.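

In this assay, within the data shown here, compound 4 returns only a limit, as compound 3 does, so no step between the two can be read, and the value joins the others at the ceiling: the limit of > 50000 nM in this assay, at which 3 of the 4 values shown sit. The compounds shown leave open whether 2,5-dimethoxyphenyl in place of 4-chlorophenyl changes the read-out at all.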